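The source may hold more compounds than are shown below. What is called first, only, known or untested is meant among the compounds shown, and "the series" means these compounds.

Measured so far:
compound 1 `Cc1c(C(=O)N/N=C\c2ccccc2O)oc2cccc(O)c12` — 10600 nM
compound 2 `Cc1c(C(=O)N/N=C\c2cc(Cl)ccc2O)oc2cccc(O)c12` — 4160 nM
compound 3 `Cc1c(C(=O)N/N=C\c2cccc(F)c2O)oc2cccc(O)c12` — 8350 nM

In a functional assay on MGC-803 cells (Homo sapiens) for inhibition, read by MTT assay (on this read-out higher numbers stand for weaker inhibition and lower numbers for stronger inhibition), compound 3 stands second highest of the three numbers. Its nearest neighbour is compound 1, separated by a 1.3-fold lower number from compound 1 to compound 3 (0.10 log units; within the scatter); the furthest is compound 2, separated by a 2.0-fold higher number from compound 2 to compound 3 (0.30 log units; within the scatter). Going by the values given here, only the step of a 2.5-fold lower number from compound 1 to compound 2 (0.41 log units; beyond the scatter) reaches beyond the scatter.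

Compound 4 `Cc1c(C(=O)N/N=C\c2ccc(O)cc2O)oc2cccc(O)c12` differs from compound 3 by 2,4-dihydroxyphenyl in place of 3-fluoro-2-hydroxyphenyl on a carbon with a double bond to nitrogen. Two of the measured steps touch this change. The step of a 1.3-fold lower number from compound 1 to compound 3 (0.10 log units; within the scatter) shows that the fluoro that now leaves made little difference, so its removal is not expected to move the number. Among the compounds with values here, the entering hydroxyl has no measured counterpart among the three compounds; the closest comparison, the step of a 2.5-fold lower number from compound 1 to compound 2 (0.41 log units; beyond the scatter), concerns chloro rather than hydroxyl and is only modest. The expectation is therefore no step beyond the scatter in this assay, with compound 4 expected near compound 1 and compound 3, as a 1.1-fold higher number from compound 3 to compound 4 (0.03 log units; within the scatter). Compound 4 is estimated at 9000 nM in this assay, with a range from 3000 nM to 27000 nM.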

Compound 4, half-maximal inhibitory concentration: 7330 nM
Compound 4: the middle estimate sits 1.2-fold (0.09 log units) above what was measured; measured number inside the range.
By their numbers in this assay, from the lowest: compounds 2, 4, 3 and 1 (each within the scatter of the next, the first and the last beyond it).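

In this assay, adding a hydroxy group stays within the scatter (a 1.4-fold lower number from compound 1 to compound 4 (0.16 log units; within the scatter)), so this added group does not separate the new compound from its parent. Exchanging 3-fluoro-2-hydroxyphenyl for 2,4-dihydroxyphenyl on the carbon with a double bond to nitrogen also stays within the scatter (a 1.1-fold lower number from compound 3 to compound 4 (0.06 log units; within the scatter)), as does the exchange of 5-chloro-2-hydroxyphenyl for the same group (a 1.8-fold higher number from compound 2 to compound 4 (0.25 log units; within the scatter)), which places the new group within the scatter of all three earlier groups. Nothing available bears on a cause for these results.

Going by these compounds, what a methoxy group, an amine or a carboxylic acid would do on this ring stays open. On these data alone, all four compounds also share the same core, so the contribution of its methyl and hydroxy groups remains open too.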